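The source may report more compounds than this note shows. Statements on the series, on what has been measured and on what is new or still open speak of the compounds shown alone.

Measured compounds:
- Compound 1, `CC(C)(C)c1ccc(CN2C(=O)S/C(=C\c3ccc(N)cc3)C2=O)cc1`: 66000 nM
- Compound 2, `Nc1cccc(/C=C2\SC(=O)N(Cc3cccc(F)c3)C2=O)c1`: 250000 nM
- Compound 3, `C=C(Br)C(=O)Nc1cccc(/C=C2\SC(=O)N(Cc3ccc(F)cc3)C2=O)c1`: 680 nM

These three share a core and were tested in a functional assay on CCRF-CEM cells (Homo sapiens) for cytotoxicity, read by cell counting, with a stated time of 3 days; on this read-out higher numbers stand for weaker inhibition and lower numbers for stronger inhibition. Compound 1 stands second highest of the three numbers: compound 2 lies above it, a gap beyond the usual scatter, while compound 3 lies far below it, again beyond the scatter. Compound 3 carries an acrylamide group on its aromatic amine and is the only one in the strongly inhibiting range.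

Compound 4, `Nc1ccc(/C=C2\SC(=O)N(Cc3ccc(F)cc3)C2=O)cc1`, has not been measured. It differs from compound 1 in one place: fluoro in place of tert-butyl on an aromatic carbon. The amine and the rest of the core are unchanged.

For the measured compounds named here, no two measured compounds differ in exactly this way, so the size of the step is uncertain. Compound 2, which also bears a fluoro on its benzyl ring though its amine sits elsewhere, gives 250000 nM, and this offers the only hint, pointing toward a somewhat weaker compound. The step from compound 1 to compound 4 is therefore expected to be a 1.7-fold higher number from compound 1 to compound 4 (0.22 log units; within the scatter), small and toward weaker inhibition. Compound 4 is estimated at 110000 nM, with a likely range from 35000 nM to 350000 nM.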

Compound 4, half-maximal inhibitory concentration: 111000 nM
Compound 4: the middle estimate sits 1.0-fold (0.00 log units) below what was measured; low and high end bracket the measured number.
By their numbers in this assay, from the lowest: compound 3; then compounds 1 and 4 (each within the scatter of the next); then compound 2.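

In this assay, for the compounds shown here, the first direct comparison at this spot on the benzyl ring is a 1.7-fold higher number from compound 1 to compound 4 (0.23 log units; within the scatter), and this step lies within the scatter, so compound 1 and compound 4 cannot be told apart. The change is large on paper: a tert-butyl group of four heavy atoms gives way to a single fluoro atom on an aromatic carbon, yet the read-out gives no sign that this swap matters when the amine is left free. Nothing measured here explains why the swap leaves so little trace in the read-out.

This is one pair, so it cannot show whether the same place would stay as quiet with other groups, such as a methoxy group, a carboxylic acid or an amine, or with a hydrogen alone. It also leaves open whether fluoro and tert-butyl would still match once the amine carries a bromo-substituted acrylamide like the one on compound 3, the group found on the only compound shown in the strongly inhibiting range.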